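Trimming a Side Chain on a Hydroxamic Acid Solubility Series

This account rests on a few compounds, and the source may have more. Where it says the series, first, only, none or still open, it means among the compounds named here.

Compound 1, `COCCNC(=O)C[C@H](NC(=O)c1ccc(C#Cc2ccccc2)cc1)C(=O)NO`: 78000 nM
Compound 2, `O=C(NC1(C(=O)NO)CCSCC1)c1ccc(C#Cc2ccccc2)cc1`: 1000 nM

In a physicochemical assay for solubility (a lower number here means a less soluble compound, a higher number a more soluble compound), compound 1 stands highest of the two measured compounds, and the gap to compound 2 lies beyond the scatter. Compound 3, `O=C(CNC(=O)c1ccc(C#Cc2ccccc2)cc1)NO`, has not yet been measured. It differs from compound 1 by hydrogen in place of ((2-methoxyethyl)carbamoyl)methyl on a saturated chain carbon bound to an amide-type nitrogen and a carbonyl carbon. Within the data shown here, nothing measured so far tests this kind of change directly, so the expectation rests on compound 1 alone. The study expects a modest drop, a 2.6-fold lower number from compound 1 to compound 3 (0.41 log units; beyond the scatter), possibly no larger than the scatter, since the shared core of compound 1 is kept intact. Compound 3 is therefore estimated at 30000 nM, with a range of 8000 nM to 120000 nM.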

Compound 3, solubility: 21000 nM
Beside the measured number, compound 3's estimate is 1.4-fold (0.15 log units) above it, within the range that was stated.
By their numbers in this assay, from the lowest: compound 2; then compound 3; then compound 1.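

In this assay, among these compounds, the exchange of ((2-methoxyethyl)carbamoyl)methyl for hydrogen gives a 3.7-fold lower number from compound 1 to compound 3 (0.57 log units; beyond the scatter) and so offers the first direct reading of this position. The whole side chain can be replaced by hydrogen at the cost of a modest step, though one beyond the scatter. No measurement at hand accounts for the step. Going by these compounds, it remains open whether a methyl group, a carboxylic acid or an amine on this saturated chain carbon would stay closer to compound 1. On these data alone, it is also open which part of the ((2-methoxyethyl)carbamoyl)methyl group carries the step.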